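Enlarging the ring on compound 2

The source may hold more compounds than are shown below. What is called first, only, known or untested is meant among the compounds shown, and "the series" means these compounds.

Of the compounds shown here, two sharing one core have been measured so far. In a functional assay on OCI-Ly10 cells (Homo sapiens) for cytotoxicity, read by CCK-8 assay, with a stated time of 72 h (a lower number here means a stronger inhibitor, a higher number a weaker inhibitor), compound 1 `Cn1cc(NC(=O)c2cnc3ccc(N4CCC[C@@H](N)C4)nn23)c(C(F)F)n1` gives 10700 nM, while compound 2 `Cn1cc(NC(=O)c2cnc3ccc(N[C@@H]4CCNC4)nn23)c(C(F)F)n1` gives 3600 nM, the lower of the two numbers and so the stronger inhibitor. Compound 3 `Cn1cc(NC(=O)c2cnc3ccc(N[C@@H]4CCCCNC4)nn23)c(C(F)F)n1` keeps the core but carries azepan-3-yl in place of pyrrolidin-3-yl on a nitrogen on an aromatic ring. Within the data shown here, only one measured step bears on this, and only loosely: a 3.0-fold lower number from compound 1 to compound 2 (0.47 log units; beyond the scatter), a modest change, came with (pyrrolidin-3-yl)amino replacing 3-aminopiperidin-1-yl. Among the measured compounds shown here, no measured compound carries azepan-3-yl. A step no larger than that one is therefore expected, probably towards a higher number and possibly within the scatter. For compound 3 the estimated value is 5000 nM, with an expected range of 1500 nM to 15000 nM. This estimate amounts to an expected 1.4-fold higher number from compound 2 to compound 3 (0.14 log units; within the scatter).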

Compound 3, half-maximal inhibitory concentration: 800 nM
The estimate for compound 3 lay 6.3-fold (0.80 log units) above the measured number; measured number below the stated range.
By their numbers in this assay, from the lowest: compound 3; then compound 2; then compound 1.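

On the nitrogen on the aromatic ring, the seven-membered azepan-3-yl ring is clearly tolerated in this assay and is better than the five-membered pyrrolidin-3-yl ring, with a 4.5-fold lower number from compound 2 to compound 3 (0.65 log units; beyond the scatter) as the change, so adding ring atoms here does not cost activity in this pair. Measured against the 3-aminopiperidin-1-yl group on an aromatic carbon, the (azepan-3-yl)amino group gives a 13-fold lower number from compound 1 to compound 3 (1.13 log units; beyond the scatter) and makes compound 3 the strongest inhibitor of the three. Nothing is available to show why the larger ring gives the lower number.

The compounds shown leave open how a piperidin-3-yl ring on the same nitrogen would compare with these two ring sizes. Also open, going by these compounds, is what the mirror-image form of azepan-3-yl, or a methyl group on its ring nitrogen, would do to the number.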